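This account rests on a few compounds, and the source may have more. Where it says the series, first, only, none or still open, it means among the compounds named here.

Compound 2 `COc1cc(C(c2ccc(O)c(OC)c2)[C@H](C)[C@@H](C)CF)ccc1O` is the only one of the two measured compounds that yields a number in a functional assay on HeLa cells (Homo sapiens) for cytotoxicity, read by WST assay, with a stated time of 48 h (on this read-out lower numbers stand for stronger inhibition and higher numbers for weaker inhibition), where compound 2 gives 34000 nM. Compound 1 `COc1cc(C(c2ccc(O)c(OC)c2)[C@@H](C)[C@H](C)CO)ccc1O` returns only a limit of that assay, > 100000 nM. Between them lies an at least 2.9-fold lower number from compound 1 to compound 2 (0.46 log units; beyond the scatter), a step whose size rests on (the limit of > 100000 nM in this assay, at which 1 of the 2 values shown sits). Compound 3 `COc1cc(C(c2ccc(O)c(OC)c2)[C@@H](CF)C(C)C)ccc1O` has not yet been measured in this assay. It differs from compound 2 as follows: 1-(fluoromethyl)-2-methylpropyl in place of 2-(fluoromethyl)-1-methylpropyl on a saturated chain carbon bound to two aromatic carbons. For the measured compounds named here, the two compounds carry the same atoms, joined differently, and both keep the fluoromethyl group that distinguished compound 2 from compound 1; the single measured step therefore speaks only to the exchange of hydroxymethyl for fluoromethyl and says nothing about how the saturated chain is branched. Going by the values given here, no measured step bears directly on this rearrangement, so no step beyond the scatter is expected, and the estimate is kept close to compound 2. Compound 3 is accordingly estimated at 40000 nM, within a range of 15000 nM to 100000 nM, which corresponds to an expected step of a 1.2-fold higher number from compound 2 to compound 3 (0.07 log units; within the scatter) that should stay within the scatter.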

Compound 3, half-maximal inhibitory concentration: 41000 nM
Compound 3: the middle estimate sits 1.0-fold (0.01 log units) below what was measured; low and high end bracket the measured number.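

In this assay, the change to 1-(fluoromethyl)-2-methylpropyl in place of 2-(fluoromethyl)-1-methylpropyl on a saturated chain carbon bound to two aromatic carbons gives a 1.2-fold higher number from compound 2 to compound 3 (0.08 log units; within the scatter). For the compounds shown here, at this position, then, rearranging the branched chain, which also goes from 2 defined stereocentres to 1, leaves the read-out within the scatter, something the single earlier step could not show. Compound 3 also shows that a second fluoromethyl-bearing chain separates from the hydroxymethyl chain of compound 1, with an at least 2.4-fold lower number from compound 1 to compound 3 (0.38 log units; beyond the scatter), and the size of this step is open-ended, as it rests on a limit: the limit of > 100000 nM in this assay, at which 1 of the 3 values shown sits.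

The compounds shown leave open whether other groups on the chain, such as an aminomethyl, a chloromethyl or a longer chain, would also stay close to compound 2 and compound 3 or would shift the number in either direction. They also leave open how far the result depends on the spatial arrangement at the defined stereocentres, since each chain appears here in one arrangement only.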